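Five-membered ring swap at the shared core

The source may report more compounds than this note shows. Statements on the series, on what has been measured and on what is new or still open speak of the compounds shown alone.

Among the compounds with values here, compound 2, `Cc1nc(-c2noc(-c3cc(O)c(O)c([N+](=O)[O-])c3)n2)cs1`, stands highest of the two numbers measured so far in a functional assay on the whole organism (liver, strain NMRI) for inhibition, with Mus musculus as the target, with a stated time of 3 h, at a dose of 3 mg/kg by the oral route; on this read-out lower numbers stand for less inhibition and higher numbers for more inhibition at the one dose given (going by the name of the read-out): compound 2 gives 22.9%. Within the data shown here, the nearest number belongs to compound 1, `O=[N+]([O-])c1cc(-c2nc(-c3ccc(Cl)c(Cl)c3)no2)cc(O)c1O`, which in this assay gives 8.8%; the step of a number 14.1 percentage points higher from compound 1 to compound 2 (beyond the scatter) is the only measured step.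

Compound 3, `O=[N+]([O-])c1cc(-c2nc(-c3cccs3)no2)cc(O)c1O`, is not yet measured. It differs from compound 2 in one place: thiophen-2-yl in place of 2-methyl-1,3-thiazol-4-yl on an aromatic carbon. The entering group sits on an aromatic carbon of a five-membered aromatic ring with 2 nitrogen and 1 oxygen, between two ring nitrogen atoms.

Only the measured step of a number 14.1 percentage points higher from compound 1 to compound 2 (beyond the scatter) bears on this change, and only loosely: there 3,4-dichlorophenyl gave way to 2-methyl-1,3-thiazol-4-yl, whereas here that same 2-methyl-1,3-thiazol-4-yl gives way to thiophen-2-yl, a ring with one hetero atom fewer. A single step of this kind is a thin base, so a modest move back toward the lower number is expected, a number 7.9 percentage points lower from compound 2 to compound 3 (within the scatter), close to the scatter. Compound 3 is therefore estimated at 15%, with a range from 4% to 28%.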

Compound 3, a percentage reported as inhibition, in the whole organism at one dose (the size of the read-out at that dose, not a potency): 29.6%
The estimate for compound 3 lay 14.6 percentage points below the measured number; the whole stated range lies below it.
By their numbers in this assay, from the lowest: compound 1; then compounds 2 and 3 (each within the scatter of the next).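

At this position, on an aromatic carbon between two ring nitrogen atoms, the read-out in this assay does not separate thiophen-2-yl from 2-methyl-1,3-thiazol-4-yl: the step is a number 6.7 percentage points higher from compound 2 to compound 3 (within the scatter), so a ring with 1 hetero atom and a ring with 2 hetero atoms, the latter carrying a methyl group, read alike here. With a number 20.8 percentage points higher from compound 1 to compound 3 (beyond the scatter) alongside the earlier step from 3,4-dichlorophenyl, both five-membered aromatic rings now stand apart from 3,4-dichlorophenyl by more than the scatter, so the gap to compound 1 no longer rests on a single replacement. No supporting measurement is available to explain either step.

The compounds shown leave open whether that gap follows the phenyl ring itself or its chloro groups, a question that plain phenyl at the same carbon would address. Also open, as far as these compounds go, is how a group of another kind, such as a carboxylic acid, an amine or a longer alkyl chain, would read at this position.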